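From Methyl to Chloro on Compound 3

This account rests on a few compounds, and the source may have more. Where it says the series, first, only, none or still open, it means among the compounds named here.

In a functional assay on MCF7 cells (Homo sapiens) for cytotoxicity, read by CellTiter-Glo, with a stated time of 5 days (on this read-out lower numbers stand for stronger inhibition and higher numbers for weaker inhibition), compound 1 `CC/C(=C(/c1ccc(/C=C/C(=O)O)cc1)c1ccc2[nH]ncc2c1)c1ccc(Cl)cc1` gives 15 nM, compound 2 `CC/C(=C(/c1ccc(/C=C/C(=O)O)cc1)c1ccc2[nH]ncc2c1)c1ccccc1OC` gives 25 nM and compound 3 `CC/C(=C(/c1ccc(/C=C/C(=O)O)cc1)c1ccc2[nH]ncc2c1)c1ccncc1C` gives 16 nM. Compound 3 therefore stands among three values that lie within the scatter of one another. Compound 4 `CC/C(=C(/c1ccc(/C=C/C(=O)O)cc1)c1ccc2[nH]ncc2c1)c1ccncc1Cl` has chloro in place of methyl on an aromatic carbon. Within the data shown here, no measured step makes this exact exchange. The closest evidence comes from replacing the whole group that carries this position, which gave a 1.1-fold higher number from compound 1 to compound 3 (0.03 log units; within the scatter) and a 1.6-fold lower number from compound 2 to compound 3 (0.19 log units; within the scatter). The third step among these compounds is a 1.7-fold higher number from compound 1 to compound 2 (0.22 log units; within the scatter). With all three steps this small, no change beyond the scatter is expected. The estimated step is no change at the digits printed from compound 3 to compound 4 (within the scatter). Compound 4 is expected to give 16 nM, with an estimated range of 7 nM to 35 nM.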

Compound 4, half-maximal inhibitory concentration: 4 nM
For compound 4 the middle estimate is 4.0-fold (0.60 log units) above the measured one; measured number below the stated range.
By their numbers in this assay, from the lowest: compound 4; then compounds 1, 3 and 2 (each within the scatter of the next).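

In this assay, replacing whole groups had moved nothing beyond the scatter, yet exchanging only methyl for chloro gives a clear step (a 4.0-fold lower number from compound 3 to compound 4 (0.60 log units; beyond the scatter)), so this single position matters more than those swaps suggested. The 3-chloropyridin-4-yl group also stands apart from the two other groups compared, both by steps beyond the scatter (a 6.3-fold lower number from compound 2 to compound 4 (0.80 log units; beyond the scatter); a 3.8-fold lower number from compound 1 to compound 4 (0.57 log units; beyond the scatter)). No measurement available here explains this gain. As far as these compounds go, whether it is particular to chloro stays open, as bromo, fluoro or a nitrile in this same place would be needed to tell.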